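The source may hold more compounds than are shown below. What is called first, only, known or untested is meant among the compounds shown, and "the series" means these compounds.

Series notes. In a physicochemical assay for solubility, in phosphate buffer, with a stated time of 18 h (a lower number here means a less soluble compound, a higher number a more soluble compound), compound 1 `N#Cc1c(N)nc2nc(C3CCC3)ncc2c1N` gives 217000 nM and compound 2 `N#Cc1c(N)nc2nc(C3CCCCC3)ncc2c1N` gives 81000 nM. Among the measured compounds shown here, the step between them, a 2.7-fold lower number from compound 1 to compound 2 (0.43 log units; beyond the scatter), is the only change in this assay with a number on both sides. Compound 3 `CC(C)(C)c1nc(C2CCCC2)c2c(N)c(C#N)c(N)nc2n1` gives only a limit in this assay, < 1000 nM. That limit is the limit of < 1000 nM in this assay, at which 1 of the 3 values shown sits, so compound 3 is known no further than that boundary. Compound 4 `Cc1c[nH]c(-c2nc(C(C)(C)C)nc3nc(N)c(C#N)c(N)c23)n1` has not yet been measured and differs from compound 3 by 4-methyl-1H-imidazol-2-yl in place of cyclopentyl on an aromatic carbon. For the measured compounds named here, no measured step covers an exchange of this kind; the single measured step concerns ring size alone and offers no direct guide, so neither the direction nor the size of the change in this assay can be read from the numbers. With compound 3 at the limit, the estimate for compound 4 can only be loosely placed: it is estimated at 3000 nM, within 500 nM to 20000 nM. The expected step of an at least 3.0-fold higher number from compound 3 to compound 4 (0.47 log units; beyond the scatter) is thus a modest rise in solubility, held with low confidence.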

Compound 4, solubility: 5000 nM
Compound 4: the middle estimate sits 1.7-fold (0.22 log units) below what was measured; the measured number falls inside the stated range.
By their numbers in this assay, from the lowest: compound 4; then compound 2; then compound 1. At a limit, below all of these: compound 3.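

The exchange of cyclopentyl for 4-methyl-1H-imidazol-2-yl on this aromatic carbon, next to the ring nitrogen and meta to a tert-butyl group, gives in this assay an at least 5.0-fold higher number from compound 3 to compound 4 (0.69 log units; beyond the scatter), a change of ring type rather than of ring size alone. The entering group counts 1 hydrogen-bond donor and 1 hydrogen-bond acceptor and the leaving group none, but this single pair does not separate those counts from the change of ring. The step can be read only as a lower bound because compound 3 stands at a limit of the assay: the limit of < 1000 nM in this assay, at which 1 of the 4 values shown sits.

Still open, from the compounds shown here alone, is whether the ring nitrogens or the methyl carry the step, which 1H-imidazol-2-yl without the methyl or a phenyl ring on this carbon would address. Also open, going by these compounds, is whether a morpholine or a simple amine here would move the number the same way.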